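Working notes: from compound 2 to compound 3

The compounds below may be only part of what the source reports. "The series", "measured", "known", "first", "only" and "open" are said of these compounds alone.

Values in a functional assay on L1210 cells (Mus musculus) for inhibition; on this read-out lower numbers stand for stronger inhibition and higher numbers for weaker inhibition:
- compound 1 `CC(C)CN(CC(=O)N(CC(C)C)NC(=O)OCc1ccccc1)NC(=O)CBr`: 6500 nM
- compound 2 `CC(C)CN(CC(=O)N(CC(C)C)NC(=O)OCc1ccccc1)NC(=O)CNNC(=O)CBr`: 7600 nM
- compound 3 `CC(C)CN(CC(=O)N(CC(C)C)NC(=O)OCc1ccccc1)/N=C/c1cccc(B(O)O)c1`: not yet measured

In this assay compound 2 stands at 7600 nM, within the scatter of compound 1. The change under consideration is a group of 11 heavy atoms (7 carbon, 1 boron, 1 nitrogen, 2 oxygen; one six-membered aromatic ring of carbon only) in place of a group of 10 heavy atoms (4 carbon, 3 nitrogen, 2 oxygen, 1 bromine; no ring), on an amine nitrogen. For the measured compounds named here, the only measured step is a 1.2-fold higher number from compound 1 to compound 2 (0.07 log units; within the scatter), where a group of 6 heavy atoms took the place of one bromine atom. Both of those compounds still hold bromine, whereas compound 3 holds none, so that small step offers only weak guidance. Going by the values given here, no measured compound carries a six-membered aromatic ring of carbon only on this amine nitrogen. A move to a higher number, beyond the scatter, is expected, with its size poorly fixed. The estimated change is a 2.6-fold higher number from compound 2 to compound 3 (0.42 log units; beyond the scatter). The estimated value for compound 3 is 20000 nM, with an expected range of 5000 nM to 80000 nM.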

Compound 3, half-maximal inhibitory concentration: 21200 nM
For compound 3 the middle estimate is 1.1-fold (0.03 log units) below the measured one, within the range that was stated.
By their numbers in this assay, from the lowest: compounds 1 and 2 (each within the scatter of the next); then compound 3.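

In this assay, for the compounds shown here, the group with one six-membered aromatic ring of carbon only, placed on the amine nitrogen, gives the only steps in this set that lie beyond the scatter (a 2.8-fold higher number from compound 2 to compound 3 (0.45 log units; beyond the scatter)) and (a 3.3-fold higher number from compound 1 to compound 3 (0.51 log units; beyond the scatter)). Compound 3, which holds no bromine, still gives a measurable value of 21200 nM, so a read-out in this assay does not depend on bromine being present, although the number is higher than for the two bromine-holding compounds. No measured evidence bears on what lies behind this step.

From the compounds shown here alone, the steps change bromine, chain and ring together, so the share of each in the higher number stays open. Also open, going by these compounds, is how a chloroacetyl group, or the same aromatic ring carrying a carboxylic acid in place of the boron group, would read on this amine nitrogen.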